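The source may report more compounds than this note shows. Statements on the series, on what has been measured and on what is new or still open speak of the compounds shown alone.

The series rests on a shared core, seen in compound 1 `CC1CN(c2nc3c(cc2[N+](=O)[O-])c(=O)c(C(=O)O)cn3-c2ccc(F)cc2)CC(C)O1`, which in an ADME assay on Vero cells (Chlorocebus sabaeus) for cytotoxicity, read by MTT assay, with a stated time of 72 h (on this read-out lower numbers stand for stronger inhibition and higher numbers for weaker inhibition), gives 141000 nM. Compound 3 `CC1CN(c2nc3c(cc2[N+](=O)[O-])c(=O)c(C(=O)O)cn3C(C)(C)C)CC(C)O1` carries tert-butyl in place of 4-fluorophenyl on an aromatic nitrogen and in this assay gives 159000 nM; that change made a 1.1-fold higher number from compound 1 to compound 3 (0.05 log units; within the scatter). Compound 2 `O=C(O)c1cn(-c2ccc(F)cc2)c2nc(N3CCC(N4CCCCC4)CC3)c([N+](=O)[O-])cc2c1=O` differs from compound 1 in its core by 4-(piperidin-1-yl)piperidin-1-yl in place of 2,6-dimethylmorpholin-4-yl on an aromatic carbon. In this assay compound 2 reached only a limit of the assay, > 126000 nM. Because of the limit of > 126000 nM in this assay, at which 1 of the 3 values shown sits, the step that the limit leaves unreadable from compound 1 to compound 2 cannot be read, and all that the pair shows is that compound 1 sits at a measured number while compound 2 does not.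

Compound 4 `CC(C)(C)n1cc(C(=O)O)c(=O)c2cc([N+](=O)[O-])c(N3CCC(N4CCCCC4)CC3)nc21` has not yet been measured. Within the data shown here, it differs from compound 2 by tert-butyl in place of 4-fluorophenyl on an aromatic nitrogen, the same change, at a place described in the same words, as the one separating compound 1 from compound 3. From compound 2 to compound 4 the step in this assay is expected to be a step that the limit leaves unreadable from compound 2 to compound 4, an expectation resting on the step of a 1.1-fold higher number from compound 1 to compound 3 (0.05 log units; within the scatter), which stayed within the scatter of repeated measurements. Compound 4 is accordingly estimated to give 150000 nM in this assay, with a likely range from 75000 nM to 320000 nM. Given (the limit of > 126000 nM in this assay, at which 1 of the 3 values shown sits), there is a fair chance that compound 4, like compound 2, will return only a limit rather than a number.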

Compound 4, half-maximal inhibitory concentration: > 136000 nM
Compound 4 gave a limit, no number (the forecaster's own chance of this, stated with the estimate: 55%); the middle value is on the limit's open side.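

In this assay compound 4 returned only a limit, > 136000 nM. Compound 2 also stands at a limit, > 126000 nM. With no number for either compound, no step can be read between compound 2 and compound 4. The compounds shown leave open what tert-butyl in place of 4-fluorophenyl on an aromatic nitrogen does to the number when 4-(piperidin-1-yl)piperidin-1-yl is present.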